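The source may hold more compounds than are shown below. What is called first, only, known or untested is meant among the compounds shown, and "the series" means these compounds.

Measured in a functional assay on LNCaP cells (Homo sapiens) for antiproliferative activity, read by propidium iodide staining, with a stated time of 96 h; on this read-out higher numbers stand for weaker inhibition and lower numbers for stronger inhibition:
compound 1 `CC(O)(CSc1cccc(C(F)(F)F)c1)C(=O)Nc1ccc(S(F)(F)(F)(F)F)cc1` gives 18300 nM
compound 2 `CC(O)(CSc1ccccc1C(F)(F)F)C(=O)Nc1ccc(S(F)(F)(F)(F)F)cc1` gives 12300 nM
compound 3 `CC(O)(CSc1cccc(OC(F)(F)F)c1)C(=O)Nc1ccc(S(F)(F)(F)(F)F)cc1` gives 12800 nM

Compound 1 and compound 2 have the same atoms joined differently; the difference between the two cores is 2-(trifluoromethyl)phenyl in place of 3-(trifluoromethyl)phenyl on a sulfur, and the step is a 1.5-fold lower number from compound 1 to compound 2 (0.17 log units; within the scatter). From compound 1 to compound 3 the change is trifluoromethoxy in place of trifluoromethyl on an aromatic carbon, with a step of a 1.4-fold lower number from compound 1 to compound 3 (0.16 log units; within the scatter). Compound 4 `CC(O)(CSc1ccccc1OC(F)(F)F)C(=O)Nc1ccc(S(F)(F)(F)(F)F)cc1` is not yet measured in this assay; it differs from compound 2 by trifluoromethoxy in place of trifluoromethyl on an aromatic carbon. This is the same kind of change as that from compound 1 to compound 3, not the same: there the place is meta to a large group, here ortho to a large group. The step from compound 2 to compound 4 is expected to be a 1.2-fold lower number from compound 2 to compound 4 (0.09 log units; within the scatter). This rests on the earlier step of a 1.4-fold lower number from compound 1 to compound 3 (0.16 log units; within the scatter) and on compound 2 giving 12300 nM. Compound 4 is estimated at 10000 nM, expected between 5000 nM and 22000 nM.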

Compound 4, half-maximal inhibitory concentration: 10600 nM
For compound 4 the middle estimate is 1.1-fold (0.03 log units) below the measured one; low and high end bracket the measured number.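

In this assay, trifluoromethoxy in place of trifluoromethyl on an aromatic carbon, ortho to a large group, gives a 1.2-fold lower number from compound 2 to compound 4 (0.06 log units; within the scatter). Set beside the earlier step, the change reads alike on both cores: the same change on two cores in this assay, a 1.4-fold lower number (0.16 log units; within the scatter) from compound 1 to compound 3 and a 1.2-fold lower number (0.06 log units; within the scatter) from compound 2 to compound 4, 1.2-fold (0.09 log units) apart, within the scatter of two such steps. This supports carrying the change between these two cores with no step beyond the scatter, but both steps are small, so it does not show a real gain from trifluoromethoxy or predict the outcome on any other core.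

The compounds shown leave open how a nitrile or an amine would read on the same aromatic carbon. Also open, going by these compounds, is whether the same change stays this small with a sulfone in place of the sulfur.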